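Fluoro for methyl on the core of compound 1

The source may report more compounds than this note shows. Statements on the series, on what has been measured and on what is new or still open speak of the compounds shown alone.

The measured compounds and their cytotoxicity values:
- compound 1, `Cc1ccc2c(c1)/C(=N/NC(=S)NO)C(=O)N2CN1CCN(c2ccccc2)CC1`: 420000 nM
- compound 2, `CONC(=S)N/N=C1\C(=O)N(CN2CCN(c3ccccc3)CC2)c2ccc(Cl)cc21`: 267000 nM
- compound 3, `Cc1ccc2c(c1)/C(=N/NC(=S)NO)C(=O)N2CN1CCN(c2ccc(Cl)cc2)CC1`: 335000 nM

In an ADME assay on MT4 cells (Homo sapiens) for cytotoxicity, read by spectrophotometry, with a stated time of 5 days (on this read-out higher numbers stand for lower toxicity in this test and lower numbers for higher toxicity in this test), compound 1 gives the highest of the three numbers, yet its distances to the other two are small: the step of a 1.3-fold lower number from compound 1 to compound 3 (0.10 log units; within the scatter) lies within the scatter, and the gap to compound 2 is also within the scatter, so the three compounds cannot be ordered on this read-out.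

Compound 4, `O=C1/C(=N\NC(=S)NO)c2cc(F)ccc2N1CN1CCN(c2ccccc2)CC1`, has not yet been measured. Its difference from compound 1 is fluoro in place of methyl on an aromatic carbon. Among the compounds with values here, no measured step swaps a methyl for a fluoro; the only single-change step available, the chloro for hydrogen on an aromatic carbon in a 1.3-fold lower number from compound 1 to compound 3 (0.10 log units; within the scatter), left this assay essentially unchanged. Compound 2, which carries a chloro where compound 1 carries a methyl together with a second change, also sits within the scatter of compound 1. On this basis no step beyond the scatter is expected: compound 4 is estimated at 370000 nM, with a likely range from 190000 nM to 720000 nM. The expected step of a 1.1-fold lower number from compound 1 to compound 4 (0.06 log units; within the scatter) is therefore small.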

Compound 4, half-maximal cytotoxic concentration: 251000 nM
Estimate against measurement, compound 4: 1.5-fold (0.17 log units) above; the measured number falls inside the stated range.
By their numbers in this assay, from the lowest: compounds 4, 2, 3 and 1 (each within the scatter of the next).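

Read in this assay, the swap of fluoro for methyl on an aromatic carbon of the shared core (a 1.7-fold lower number from compound 1 to compound 4 (0.22 log units; within the scatter)) gives the first direct look at this position, and the step lies within the scatter. The only earlier single-change step involved a chloro in place of hydrogen at another place, so only now is it shown that this position accepts fluoro for methyl with no readable difference on this read-out. Nothing available offers an explanation for this result.

The compounds shown leave open whether any group at this position would move the number beyond the scatter, for example an amine, a carboxylic acid or a longer chain such as propyl. They also cannot tell how this swap would behave in any read-out other than cytotoxicity.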